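This account rests on a few compounds, and the source may have more. Where it says the series, first, only, none or still open, it means among the compounds named here.

Measured so far in a functional assay on U-87MG ATCC cells (Homo sapiens) for cytotoxicity, read by MTT assay, with a stated time of 72 h; a higher number here means a weaker inhibitor, a lower number a stronger inhibitor:
- compound 1 `CN(C)CCn1cnnc1-c1cc(Oc2ccc(NC(=O)N/N=C/c3cc(C(C)(C)C)cc(C(C)(C)C)c3O)cc2F)ccn1`: 520 nM
- compound 2 `CN(C)CCn1cnnc1-c1cc(Oc2ccc(NC(=O)N/N=C/c3ccc(O)cc3)cc2F)ccn1`: 7750 nM
- compound 3 `CN(C)CCn1cnnc1-c1cc(Oc2ccc(NC(=O)N/N=C/c3ccc(O)c(Br)c3)cc2F)ccn1`: 12400 nM

Compound 3 has the highest of the three numbers. Its nearest neighbour is compound 2, from which the step to compound 3 is a 1.6-fold higher number from compound 2 to compound 3 (0.20 log units; within the scatter), a change of bromo in place of hydrogen on an aromatic carbon. Among the compounds with values here, compound 1, which carries the 3,5-di-tert-butyl-4-hydroxyphenyl group on the same shared core, gives a far lower number, but no single-place step links it to compound 3, so only its value can be set against that of compound 3.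

Compound 4 `CN(C)CCn1cnnc1-c1cc(Oc2ccc(NC(=O)N/N=C/c3c(Cl)cccc3Cl)cc2F)ccn1` is the next member, not yet measured in this assay. It differs from compound 3 by 2,6-dichlorophenyl in place of 3-bromo-4-hydroxyphenyl on a carbon with a double bond to nitrogen. Within the data shown here, no measured step covers the loss of the hydroxy group together with the arrival of two chlorines. Among the measured compounds shown here, the one measured step, from compound 2 to compound 3, stayed within the scatter, and compound 1 shows that a different substitution of this phenyl can move the number a long way down. For the measured compounds named here, with no direct precedent, the expectation for compound 4 is a step of a 2.1-fold lower number from compound 3 to compound 4 (0.32 log units; beyond the scatter), and its value in this assay is estimated at 6000 nM, within a range of 1500 nM to 20000 nM.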

Compound 4, half-maximal inhibitory concentration: > 100000 nM
Compound 4: only a limit was reported (the forecaster's own chance of this, stated with the estimate: 10%); middle value at least 16-fold (1.22 log units) away from the limit.
By their numbers in this assay, from the lowest: compound 1; then compounds 2 and 3 (each within the scatter of the next). At a limit, above all of these: compound 4.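

In this assay compound 4 gives a limit and not a number: the limit of > 100000 nM in this assay, at which 1 of the 4 values shown sits.

Putting 2,6-dichlorophenyl on the carbon with a double bond to nitrogen gives an at least 8.0-fold higher number from compound 3 to compound 4 (0.90 log units; beyond the scatter) in place of 3-bromo-4-hydroxyphenyl, and an at least 12-fold higher number from compound 2 to compound 4 (1.11 log units; beyond the scatter) in place of 4-hydroxyphenyl. Within the data shown here, the only earlier single-place step at this phenyl, a 1.6-fold higher number from compound 2 to compound 3 (0.20 log units; within the scatter), stayed within the scatter, so these are the first steps to show that a change at this position can raise the number beyond the scatter.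

The compounds shown do not separate the loss of the hydroxy group from the arrival of the two chlorines, as both occur in the same step. Also open, on these data alone, is how a plain phenyl, or a phenyl carrying an amine or a carboxylic acid, would read in this assay.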